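The source may hold more compounds than are shown below. What is called first, only, known or untested is meant among the compounds shown, and "the series" means these compounds.

Within the data shown here, in a functional assay on HEL cells (Homo sapiens) for cytotoxicity (on this read-out lower numbers stand for stronger inhibition and higher numbers for weaker inhibition), compound 2 `O=C1O/C(=C\Cn2ccc(=O)[nH]c2=O)C(OCc2ccccc2)=C1OCc1ccccc1` gives 5000 nM and has only one measured compound to stand against. That is compound 1 `O=C1O/C(=C\Cn2cc(I)c(=O)[nH]c2=O)C(OCc2ccccc2)=C1OCc1ccccc1` with 3000 nM on the same read-out. The two values lie within the scatter of each other, so the numbers shown do not rank them.

Compound 3 `O=C1O/C(=C\Cn2cc(Cl)c(=O)[nH]c2=O)C(OCc2ccccc2)=C1OCc1ccccc1` departs from compound 2 by one change, chloro in place of hydrogen on an aromatic carbon, counted as chloro in place of hydrogen on an aromatic carbon and placed on a six-membered aromatic ring with 2 nitrogen. Among the measured compounds shown here, one measured step bears on it. The step of a 1.7-fold higher number from compound 1 to compound 2 (0.22 log units; within the scatter) puts hydrogen in place of iodo at that same carbon, so it runs the opposite way and involves a different halogen, and it stays within the scatter. For the measured compounds named here, no chloro compound has a measured value yet, so this single small step is the whole of the evidence. On that basis the step of a 1.4-fold lower number from compound 2 to compound 3 (0.15 log units; within the scatter) is expected to stay within the scatter, with only a slight lean towards the value of compound 1. Compound 3 is therefore estimated at 3500 nM with an expected range from 1500 nM to 8000 nM on this read-out.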

Compound 3, half-maximal inhibitory concentration: 3000 nM
The estimate for compound 3 lay 1.2-fold (0.07 log units) above the measured number; low and high end bracket the measured number.
By their numbers in this assay, from the lowest: compounds 1, 3 and 2 (each within the scatter of the next).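

At this aromatic carbon of the six-membered aromatic ring with 2 nitrogen, chloro now stands as a second measured halogen. In this assay putting chloro in place of hydrogen gives a 1.7-fold lower number from compound 2 to compound 3 (0.22 log units; within the scatter) and putting chloro in place of iodo gives no change at the digits printed from compound 1 to compound 3 (within the scatter) at that same carbon. The earlier pair held only one halogen, so the new finding is that the two halogens cannot be told apart here and that neither separates from the hydrogen compound, which means that across these three compounds the position shows no readable response to what sits on it, and nothing available explains why the values lie so close.

The compounds shown leave open whether a group of more than one heavy atom at this carbon, such as a methyl, an amine or a longer chain, would move the value beyond the scatter. Whether a carboxylic acid or another change elsewhere on the shared core would do so is equally unsettled.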